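The source may hold more compounds than are shown below. What is called first, only, known or untested is meant among the compounds shown, and "the series" means these compounds.

In an assay on CHO-K1 cells for displacement of a labelled ligand from prostaglandin E2 receptor EP1 subtype (Homo sapiens) (on this read-out lower numbers stand for stronger inhibition and higher numbers for weaker inhibition), compound 2 `Cc1cc(C(=O)O)nn1Cc1cc(Br)ccc1OCc1ccc(F)cc1` gives 7.41 nM, the second highest of the three numbers in hand. Compound 1 `Cc1cc(C(=O)O)nn1Cc1cc(Br)ccc1OCc1ccccc1` gives 6.46 nM, and a 1.1-fold higher number from compound 1 to compound 2 (0.06 log units; within the scatter) is within the scatter. Compound 3 `Cc1cc(C(=O)O)nn1Cc1cc(Br)ccc1OCc1cccc(Br)c1` gives 17.8 nM; a 2.4-fold higher number from compound 2 to compound 3 (0.38 log units; beyond the scatter) and a 2.8-fold higher number from compound 1 to compound 3 (0.44 log units; beyond the scatter) both lie beyond the scatter. Compound 4 `Cc1cc(C(=O)O)nn1Cc1cc(Br)ccc1OCc1ccc(C(C)(C)C)cc1` differs from compound 2 by tert-butyl in place of fluoro on an aromatic carbon. For the measured compounds named here, no measured step swaps one group for another at this place; the steps that bear on it are a 1.1-fold higher number from compound 1 to compound 2 (0.06 log units; within the scatter) and a 2.8-fold higher number from compound 1 to compound 3 (0.44 log units; beyond the scatter), which show that what enters on this ring has given a small to modest rise in this assay. A modest rise is therefore expected, a 2.0-fold higher number from compound 2 to compound 4 (0.31 log units; beyond the scatter). Compound 4 is estimated at 15 nM, with a range of 5 nM to 45 nM.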

Compound 4, half-maximal inhibitory concentration: 1230 nM
Estimate against measurement, compound 4: 82-fold (1.91 log units) below, and the stated range ends below it.
By their numbers in this assay, from the lowest: compounds 1 and 2 (each within the scatter of the next); then compound 3; then compound 4.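

At this place, para to a large group, tert-butyl breaks from the small to modest changes seen so far in this assay and gives a 170-fold higher number from compound 2 to compound 4 (2.22 log units; beyond the scatter) and a 190-fold higher number from compound 1 to compound 4 (2.28 log units; beyond the scatter) as well. Hydrogen and fluoro are within the scatter of each other here, so the place accommodates these two but not tert-butyl, with 4 heavy atoms against 1 for fluoro. Nothing available accounts for a step of this size. Still open, on these data alone, is where between fluoro and tert-butyl the loss sets in. Methyl, ethyl or isopropyl at this place would bear on that.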